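Moving the chlorine around the benzyl ring

The source may report more compounds than this note shows. Statements on the series, on what has been measured and on what is new or still open speak of the compounds shown alone.

Working notes on the series. Compound 2 `Cc1[nH]n(-c2nc3ccccc3[nH]2)c(=O)c1Cc1ccccc1Cl` is the point of departure here. In an assay on isolated protein for inhibition of alpha-ketoglutarate-dependent dioxygenase alkB homolog 3 (Homo sapiens), read by polymerase chain reaction, with a stated time of 1 h (a higher number here means a weaker inhibitor, a lower number a stronger inhibitor), compound 2 gives > 10000 nM, which is a limit of the assay and not a number. Going by the values given here, of the three measured members, one sits at the limit (the limit of > 10000 nM in this assay, at which 1 of the 3 values shown sits). The two others carry numbers: compound 1 `Cc1[nH]n(-c2nc3cc(Cl)ccc3[nH]2)c(=O)c1Cc1ccccc1` gives 4500 nM in this assay, and compound 3 `Cc1ccc2[nH]c(-n3[nH]c(C)c(Cc4ccccc4)c3=O)nc2c1` gives 670 nM. Among the compounds with values here, the only step measured in a single place, a 6.7-fold lower number from compound 1 to compound 3 (0.83 log units; beyond the scatter), concerns the substituent on the shared core and leaves the benzyl part untouched.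

Compound 4 `Cc1[nH]n(-c2nc3ccccc3[nH]2)c(=O)c1Cc1ccc(Cl)cc1` is not yet measured in this assay. Against compound 2 it shows (4-chlorophenyl in place of 2-chlorophenyl on a saturated chain carbon bound to an aromatic carbon). Within the data shown here, no measured step bears directly on this change; the step from compound 1 to compound 3 sits elsewhere, and compound 1 and compound 3 both carry an unsubstituted benzyl group rather than either chlorobenzyl group. The size of the change in this assay therefore cannot be read off the measured steps, and a limit remains a real possibility for compound 4.

The step of an at least 1.2-fold lower number from compound 2 to compound 4 (0.09 log units; that floor lies within the scatter) is expected to run toward a lower number, but only loosely. Compound 4 is estimated at 8000 nM in this assay, with a range from 2000 nM to 30000 nM.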

Compound 4, half-maximal inhibitory concentration: > 10000 nM
Compound 4 was reported as a limit; the forecaster's own chance of this, stated with the estimate: 45%; middle value at least 1.2-fold (0.09 log units) from the limit.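

Compound 2 and compound 4 both stand at a limit of this assay and not at a number, so no step between them can be read: the limit of > 10000 nM in this assay, at which 2 of the 4 values shown sit.

The compounds shown leave open what number either compound would carry, and so whether 4-chlorobenzyl in place of 2-chlorobenzyl changes inhibition at all.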